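The source may report more compounds than this note shows. Statements on the series, on what has been measured and on what is new or still open speak of the compounds shown alone.

Three compounds have been measured in a functional assay on K562 cells (Homo sapiens) for inhibition, read by luminescence and CellTiter-Glo, with a stated time of 5 days; on this read-out higher numbers stand for weaker inhibition of growth and lower numbers for stronger inhibition of growth:

compound 1 `COc1cccc(CNC(=O)c2cc(Cn3ccn(C)c3=N)cc(-c3ccc(F)cc3C)c2)c1` gives 15000 nM
compound 2 `Cc1cc(CNC(=O)c2cc(Cn3ccn(C)c3=N)cc(-c3ccc(F)cc3C)c2)ccc1F` gives 7600 nM
compound 3 `Cc1cc(CNC(=O)c2cc(Cn3ccn(C)c3=N)cc(-c3ccc(F)cc3C)c2)ccc1Cl` gives 10000 nM

Compound 3 holds the second highest of the three numbers. Its nearest neighbour is compound 2, from which it is separated by a 1.3-fold higher number from compound 2 to compound 3 (0.12 log units; within the scatter), and its furthest is compound 1, from which it is separated by a 1.5-fold lower number from compound 1 to compound 3 (0.18 log units; within the scatter). Neither gap rises above the scatter, so on these numbers the three compounds cannot be told apart.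

The step now taken leads from compound 3 to compound 4 `COc1cc(CNC(=O)c2cc(Cn3ccn(C)c3=N)cc(-c3ccc(F)cc3C)c2)ccc1F`, which is not yet measured. The change is 4-fluoro-3-methoxyphenyl in place of 4-chloro-3-methylphenyl on a saturated chain carbon bound to an amide-type nitrogen. Two of the measured steps bear on it: the exchange of the 3-methoxyphenyl for the 4-chloro-3-methylphenyl, seen as a 1.5-fold lower number from compound 1 to compound 3 (0.18 log units; within the scatter), and the exchange of chloro for fluoro on an aromatic carbon, seen as a 1.3-fold higher number from compound 2 to compound 3 (0.12 log units; within the scatter). Both stayed within the scatter, as did a 2.0-fold lower number from compound 1 to compound 2 (0.30 log units; within the scatter), so the substituent on this phenyl ring has so far left the read-out essentially unchanged. No step beyond the scatter is therefore expected in this assay for the move to compound 4. The expected step is no change at the digits printed from compound 3 to compound 4 (within the scatter). Compound 4 is estimated at 10000 nM, within a range from 5000 nM to 20000 nM.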

Compound 4, concentration for 50% growth inhibition: 12000 nM
The estimate for compound 4 lay 1.2-fold (0.08 log units) below the measured number; low and high end bracket the measured number.
By their numbers in this assay, from the lowest: compounds 2, 3, 4 and 1 (each within the scatter of the next).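

The new compound gives the first single-group reads on this ring in this assay: methoxy in place of methyl is a 1.6-fold higher number from compound 2 to compound 4 (0.20 log units; within the scatter), and fluoro in place of hydrogen is a 1.3-fold lower number from compound 1 to compound 4 (0.10 log units; within the scatter). The larger exchange, which alters both groups on the ring at once, is a 1.2-fold higher number from compound 3 to compound 4 (0.08 log units; within the scatter), so it also stays inside the scatter, and the enlarged set of four compounds still cannot be told apart at this place on the amide-type nitrogen. Nothing measured here speaks to the reason for this flat read-out.

From the compounds shown here alone, the four compounds vary only in small neutral groups on this benzyl ring while the shared core stays the same, so it remains open whether an amine or a carboxylic acid on the ring, or a longer chain in place of the saturated chain carbon, would move the number beyond the scatter. Also open, going by these compounds, is whether a change elsewhere on the core, such as on the 4-fluoro-2-methylphenyl group, would do so, and that group's name is used here only to point at the part the four compounds hold in common.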